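One Carbon Added: Compound 3 to Compound 4

The compounds below may be only part of what the source reports. "The series", "measured", "known", "first", "only" and "open" are said of these compounds alone.

Compound 1 `CCC(C(=O)N1CCN(c2ccccc2F)CC1)N1C(=O)CCC1=O`: 0%
Compound 2 `CCC(C(=O)N1CCN(c2cccc(OC)c2)CC1)N1C(=O)CCC1=O`: 0%
Compound 3 `CC(C(=O)N1CCN(c2cccc(F)c2)CC1)N1C(=O)CCC1=O`: 100%

In a functional assay on the whole organism (strain Swiss) with Mus musculus as the target, in the maximal electroshock model, with a stated time of 2 h, at a dose of 300 mg/kg by the intraperitoneal route (a higher number here means a stronger effect of the compound at the dose given, a lower number a weaker effect), compound 3 gives 100%, the highest of the three numbers, beyond the scatter above both compound 1 and compound 2. Compound 4 `CCC(C(=O)N1CCN(c2cccc(F)c2)CC1)N1C(=O)CCC1=O` differs from compound 3 by one change: methyl in place of hydrogen on a saturated chain carbon, two bonds along the chain from an amide-type nitrogen in a ring and a carbonyl carbon. Within the data shown here, the only measured step, no change at the digits printed from compound 1 to compound 2 (within the scatter), swaps the aryl group and does not touch this chain carbon, so no measured step bears directly on the change. Compound 1 and compound 2 both carry ethyl where compound 3 carries methyl and both give no effect, but their aryl groups also differ from that of compound 3, so this is only a weak hint. Compound 4 is therefore estimated at 40%, in the range 0% to 100%, an expected step of a number 60 percentage points lower from compound 3 to compound 4 (beyond the scatter), with wide uncertainty.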

Compound 4, a percentage reported as activity, at one dose (the size of the read-out at that dose, not a potency): 0%
Compound 4: the middle estimate sits 40 percentage points above what was measured; the measured number falls inside the stated range.
By their numbers in this assay, from the lowest: compounds 1, 2 and 4 (each within the scatter of the next); then compound 3.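

Adding methyl on this saturated chain carbon gives a number 100 percentage points lower from compound 3 to compound 4 (beyond the scatter) in this assay and so this one added carbon is enough to remove the effect at this dose. With ethyl kept on the chain, changing the aromatic group gives no change at the digits printed from compound 2 to compound 4 (within the scatter) and no change at the digits printed from compound 1 to compound 4 (within the scatter) so the 3-fluorophenyl group does not restore the effect on its own.

On these data alone, whether a longer chain such as propyl or a hydroxymethyl group on this carbon would also remove the effect stays open. Nothing measured here gives a reason for the loss.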